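This account rests on a few compounds, and the source may have more. Where it says the series, first, only, none or still open, it means among the compounds named here.

Measured in a functional assay on A549 cells (Homo sapiens) for inhibition, read by MTT assay, with a stated time of 72 h; on this read-out higher numbers stand for weaker inhibition and lower numbers for stronger inhibition:
compound 1, `COc1cc2c(Oc3ccc(NC(=O)c4nn(-c5ccccc5)cc(C)c4=O)cc3F)ccnc2cc1OCCCCCC(=O)NO`, 4170 nM;
compound 2, `COc1cc2c(Oc3ccc(NC(=O)c4nn(-c5ccccc5C)cc(C)c4=O)cc3)ccnc2cc1OCCCCCC(=O)NO`, 1820 nM;
compound 3, `COc1cc2c(Oc3ccc(NC(=O)c4nn(-c5ccccc5C)ccc4=O)cc3)ccnc2cc1OCCCCCC(=O)NO`, 3920 nM.

Compound 2 gives the lowest of the three numbers. For the measured compounds named here, the one single-point step, a 2.2-fold higher number from compound 2 to compound 3 (0.33 log units; beyond the scatter), comes from hydrogen in place of methyl on an aromatic carbon and is modest. Compound 1 is not linked to compound 2 by a single change; its number simply stands higher.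

Compound 4, `COc1cc2c(Oc3ccc(NC(=O)c4nn(-c5ccccc5C)cc(C)c4=O)cc3)ccnc2cc1OCCCCCCC(=O)NO`, differs from compound 2 in one place: (hydroxycarbamoyl)methyl in place of hydroxycarbamoyl on a saturated chain carbon, five bonds along the chain from an oxygen on an aromatic ring. Going by the values given here, no measured step touches this chain; the only step known alters an aromatic substituent elsewhere. With nothing pointing either way, the number expected for compound 4 in this assay is one close to that of compound 2, a step of a 1.1-fold higher number from compound 2 to compound 4 (0.04 log units; within the scatter) that should lie within the scatter. Compound 4 is therefore estimated at 2000 nM, in the range 900 nM to 4500 nM.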

Compound 4, half-maximal inhibitory concentration: 3130 nM
Estimate against measurement, compound 4: 1.6-fold (0.19 log units) below; low and high end bracket the measured number.
By their numbers in this assay, from the lowest: compounds 2, 4, 3 and 1 (each within the scatter of the next, the first and the last beyond it).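

For the compounds shown here, this is the first reading on the chain itself: in this assay, (hydroxycarbamoyl)methyl in place of hydroxycarbamoyl gives a 1.7-fold higher number from compound 2 to compound 4 (0.24 log units; within the scatter) and so stays inside the usual variation between repeats. On the saturated chain carbon, this single added carbon therefore separates the two compounds by no clear margin. No supporting measurement bears on this result.

From the compounds shown here alone, whether a longer chain, such as one ending in 3-(hydroxycarbamoyl)propyl, would shift the number beyond the scatter remains open. So does the effect of a carboxylic acid in place of the hydroxycarbamoyl group.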